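The source may hold more compounds than are shown below. What is called first, only, known or untested is meant among the compounds shown, and "the series" means these compounds.

Working notes on the series. For the measured compounds named here, compound 1, `CCCCCCCCCCCCCCCCCCNC(=O)Oc1c(C)cccc1C`, is the only member with a number in an assay on microsomes from intestinal mucosa for inhibition of acyl-CoA:cholesterol acyltransferase (Oryctolagus cuniculus) (a higher number here means a weaker inhibitor, a lower number a stronger inhibitor), where compound 1 gives 3100 nM. Compound 2, `CCCCCCCCCCCCCCCCCCSc1c(C)cccc1C`, gives in this assay only a limit, > 10000 nM, which tells how far the measurement reaches and nothing beyond that; the limit of > 10000 nM in this assay, at which 1 of the 2 values shown sits, is the single such entry here. Going by the values given here, no pair of measured compounds differs in one place, so no measured step is available for scaling.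

Compound 3, `CCCCCCCCCCCCCCCCCCNC(=O)Nc1c(C)cccc1Cl`, is not yet measured. It differs from compound 1 by (2-chloro-6-methylphenyl)amino in place of 2,6-dimethylphenoxy on a carbonyl carbon; the long chain and the carbonyl with its amide-type nitrogen are kept.

Among the compounds with values here, with no measured step to lean on, the expectation rests on the structural change alone: the step from compound 1 to compound 3 is estimated at a 3.1-fold lower number from compound 1 to compound 3 (0.49 log units; beyond the scatter), towards stronger inhibition, and beyond the usual scatter only modestly. For compound 3 the half-maximal inhibitory concentration is expected to be 1000 nM, within 300 nM to 4000 nM.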

Compound 3, half-maximal inhibitory concentration: 1100 nM
Compound 3: middle estimate off by 1.1-fold (0.04 log units), on the low side; low and high end bracket the measured number.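

In this assay, for the compounds shown here, the change on the carbonyl carbon gives the first step that can be read, a 2.8-fold lower number from compound 1 to compound 3 (0.45 log units; beyond the scatter), so (2-chloro-6-methylphenyl)amino is accepted in place of 2,6-dimethylphenoxy with a modest move towards stronger inhibition while the long chain and the amide-type nitrogen are kept. The step changes two things at once, since the linking oxygen becomes a nitrogen that brings a hydrogen-bond donor and one ring methyl gives way to chlorine, and the measured number cannot be divided between these two changes. Nothing at hand bears on why the number moves.

The compounds shown leave open how the step divides between the link and the ring, a question that (2,6-dimethylphenyl)amino or 2-chloro-6-methylphenoxy on the same carbonyl carbon would address. Also open, as far as these compounds go, is how the number in this assay responds to the other end of the molecule, for example to a shorter chain or to a chain carrying an amine.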